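A Carbonyl for a Sulfonyl on Compound 1

A few compounds are considered here, and "the series" means these few. Any claim that something is new, unique, unknown or untested is made for them only; others in the source may bear on it.

In a functional assay on HCT-116 cells (Homo sapiens) for cytotoxicity, read by resazurin assay, with a stated time of 48 h (on this read-out higher numbers stand for an effect only at larger amounts of compound and lower numbers for an effect already at smaller amounts), compound 1 (`COc1ccc(S(=O)(=O)Nc2ccc(-c3nc4cc(NS(=O)(=O)c5ccc(OC)cc5)ccc4o3)cc2)cc1`) gives 12000 nM and compound 2 (`O=S(=O)(Nc1ccc(-c2nc3cc(NS(=O)(=O)c4ccc(Cl)s4)ccc3o2)cc1)c1ccc(Cl)c(C(F)(F)F)c1`) gives 17000 nM as its value. These two numbers lie within the scatter of each other, so compound 1 stands level with compound 2 and neither can be ranked. Compound 3 (`COc1ccc(S(=O)(=O)Nc2ccc3oc(-c4ccc(NC(=O)c5ccc(Cl)s5)cc4)nc3c2)cc1`) has not yet been measured. It differs from compound 1 in one place, with (5-chlorothiophen-2-yl)carbonyl in place of (4-methoxyphenyl)sulfonyl on a nitrogen on an aromatic ring. Among the compounds with values here, no measured pair isolates a single change of this kind. Compared with compound 1, compound 2 carries other groups and still reads 17000 nM in the same range, so no large shift is expected. The estimated change in this assay is a 1.2-fold lower number from compound 1 to compound 3 (0.08 log units; within the scatter) and is expected to stay within the scatter, with no direction favoured. For compound 3 the estimate is 10000 nM with an expected range from 3500 nM to 30000 nM on this read-out.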

Compound 3, half-maximal effective concentration: 5400 nM
Estimate against measurement, compound 3: 1.9-fold (0.27 log units) above; measured number inside the range.
By their numbers in this assay, from the lowest: compound 3; then compounds 1 and 2 (each within the scatter of the next).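

In this assay, within the data shown here, the nitrogen on an aromatic ring proves responsive to what it carries: (5-chlorothiophen-2-yl)carbonyl in place of (4-methoxyphenyl)sulfonyl gives a 2.2-fold lower number from compound 1 to compound 3 (0.35 log units; beyond the scatter) and provides the first comparison here that isolates one place. The step is modest, but it shows that the sulfonyl link and the 4-methoxyphenyl group on this nitrogen can both be given up without any loss on this read-out. No evidence is available on what lies behind this shift.

The change swaps the link and the ring together, so the compounds shown do not separate the contribution of the carbonyl from that of the 5-chlorothiophene. A (4-methoxyphenyl)carbonyl group on this nitrogen would divide the two, and a small acetyl group or the free amine would show how much of either ring is needed at all.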